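The source may hold more compounds than are shown below. What is called first, only, known or untested is meant among the compounds shown, and "the series" means these compounds.

Of the compounds shown here, three have so far been measured in an assay on HEK293 cells for displacement of a labelled ligand from Neuronal acetylcholine receptor; alpha4/beta2 (Homo sapiens); on this read-out lower numbers stand for stronger inhibition and higher numbers for weaker inhibition. Compound 1 `COc1cc(N2CCCNCC2)cnc1Cl` gives 0.676 nM, compound 2 `C/C=C\Oc1cncc(N2CCCNCC2)c1` gives 1.29 nM, and compound 3 `COc1ccc(N2CCCNCC2)cn1` gives 170 nM. Compound 2 thus holds the second highest of the three numbers: its value and that of compound 1 lie within the scatter of each other, while compound 3 sits far beyond it. Compound 4 `COc1cncc(N2CCCNCC2)c1` has not yet been measured; it differs from compound 2 by methyl in place of prop-1-en-1-yl on an oxygen on an aromatic ring. Going by the values given here, no two measured compounds differ in a single place, so there is no measured step that guides this change directly. Compound 1 and compound 3 both carry a methyl on the oxygen on the aromatic ring and still sit far apart in this assay, so the remainder of the structure seems to weigh more than the group on that oxygen. For that reason the step expected is a 1.9-fold higher number from compound 2 to compound 4 (0.29 log units; within the scatter), either within the scatter or a modest rise. The estimate for compound 4 is 2.5 nM, with an expected range from 0.6 nM to 10 nM.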

Compound 4, half-maximal inhibitory concentration: 1.91 nM
Compound 4: the middle estimate sits 1.3-fold (0.12 log units) above what was measured; low and high end bracket the measured number.
By their numbers in this assay, from the lowest: compounds 1, 2 and 4 (each within the scatter of the next, the first and the last beyond it); then compound 3.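

In this assay, methyl and prop-1-en-1-yl on an oxygen on an aromatic ring cannot be told apart: the step is a 1.5-fold higher number from compound 2 to compound 4 (0.17 log units; within the scatter), so this place tolerates both the smaller group and the larger one with its double bond, at least in this pair. Going by these compounds alone, the chloro on an aromatic carbon gives the first single-place comparison that clears the scatter, with hydrogen in its place producing a 2.8-fold higher number from compound 1 to compound 4 (0.45 log units; beyond the scatter), a modest step that shows this substituent has a measurable bearing on the number. The data offer no explanation for either step.

As far as these compounds go, whether a longer chain such as butyl or a cyclopropyl ring on that oxygen would also leave the number unchanged remains open. So does whether fluoro, bromo or a nitrile in place of the chloro would read like chloro or like hydrogen.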